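Aryl swap on the shared core: formyl lost, fluorine enters

This account rests on a few compounds, and the source may have more. Where it says the series, first, only, none or still open, it means among the compounds named here.

Compound 2 `O=Cc1ccc(-c2cn3ccnc3c(-c3ccc4ncn(C5CCCCC5)c4c3)n2)cc1` stands highest of the three in a functional assay on DU-145 cells (Homo sapiens) for inhibition, read by sulforhodamine B assay, with a stated time of 48 h, tested at 10 uM (on this read-out lower numbers stand for less inhibition and higher numbers for more inhibition at the one concentration tested (going by the name of the read-out)), where compound 2 gives 24.3%. Compound 1 `Brc1cn2ccnc2c(-c2ccc3ncn(C4CCCCC4)c3c2)n1` gives 6.2% and compound 3 `Brc1ccc(-c2cn3ccnc3c(-c3ccc4ncn(C5CCCCC5)c4c3)n2)cc1` gives 5.66%; these two lie within the scatter of each other, a number 0.5 percentage points lower from compound 1 to compound 3 (within the scatter). Compound 4 `Fc1ccccc1-c1cn2ccnc2c(-c2ccc3ncn(C4CCCCC4)c3c2)n1` differs from compound 2 by 2-fluorophenyl in place of 4-formylphenyl on an aromatic carbon. Among the measured compounds shown here, the steps that bear on this are a number 18.1 percentage points higher from compound 1 to compound 2 (beyond the scatter) and a number 18.6 percentage points lower from compound 2 to compound 3 (beyond the scatter); compound 1 and compound 3 show that a phenyl ring without the formyl group adds nothing beyond the scatter. The 2-fluorophenyl group carries no hydrogen-bond acceptor, so a downward step of about the size of a number 18.6 percentage points lower from compound 2 to compound 3 (beyond the scatter) is expected. Compound 4 is expected at 8%, with a range from 0% to 20%, meaning an expected step of a number 16.3 percentage points lower from compound 2 to compound 4 (beyond the scatter).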

Compound 4, a percentage reported as inhibition, at one concentration (the size of the read-out at that concentration, not a potency): 0.96%
Beside the measured number, compound 4's estimate is 7 percentage points above it; the range from low to high includes it.
By their numbers in this assay, from the lowest: compounds 4, 3 and 1 (each within the scatter of the next); then compound 2.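

In this assay, 2-fluorophenyl at this position does not keep the level reached with 4-formylphenyl (a number 23.3 percentage points lower from compound 2 to compound 4 (beyond the scatter)). Against the two bromo-bearing compounds it shows no separation (a number 4.7 percentage points lower from compound 3 to compound 4 (within the scatter); a number 5.2 percentage points lower from compound 1 to compound 4 (within the scatter)), so a second aryl group without the formyl group joins them, and compound 2 alone stands apart in this set. Nothing available explains why the formyl-bearing compound stands apart.

Still open, on these data alone, is whether a 4-carboxyphenyl or 4-aminophenyl group would match compound 2. A 4-fluorophenyl group would separate the effect of the fluorine from that of its place on the ring.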